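Swapping the Benzoyl Ester for an Acetyl Ester

The compounds below may be only part of what the source reports. "The series", "measured", "known", "first", "only" and "open" are said of these compounds alone.

compound 1 `O=C(OC1(C(=O)Nc2ccc([N+](=O)[O-])cc2)CCCCC1)c1ccccc1I`: 396 nM
compound 2 `O=C(OC1(C(=O)Nc2ccc([N+](=O)[O-])cc2)CCCCC1)c1ccccc1`: 246 nM

In an ADME assay on WI-38 cells (Homo sapiens) for inhibition, read by MTT assay, with a stated time of 72 h (a higher number here means a weaker inhibitor, a lower number a stronger inhibitor), compound 1 gives 396 nM, and compound 2 gives 246 nM. Among the compounds with values here, the one measured step, a 1.6-fold lower number from compound 1 to compound 2 (0.21 log units; within the scatter), came from replacing iodo with hydrogen on an aromatic carbon. Compound 2 thus holds the lowest of the two numbers, but its separation from compound 1 is within the scatter, so no order between them can be claimed.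

Compound 3 `CC(=O)OC1(C(=O)Nc2ccc([N+](=O)[O-])cc2)CCCCC1` differs from compound 2 by methyl in place of phenyl on a carbonyl carbon. Within the data shown here, no measured step touches the ester side of the molecule; the only step available concerns the aromatic ring of the anilide and was within the scatter, so it gives no direct guide. On that thin basis, compound 3 is expected to show a step of a 2.0-fold higher number from compound 2 to compound 3 (0.31 log units; beyond the scatter), with a wide range allowed. The estimate for compound 3 is 500 nM, expected to lie between 150 nM and 2000 nM.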

Compound 3, half-maximal inhibitory concentration: 386 nM
Estimate against measurement, compound 3: 1.3-fold (0.11 log units) above; low and high end bracket the measured number.
By their numbers in this assay, from the lowest: compounds 2, 3 and 1 (each within the scatter of the next).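

Across the three compounds, the carbonyl carbon of the ester carries phenyl, 2-iodophenyl or methyl, and this assay does not separate them: there is a 1.6-fold higher number from compound 2 to compound 3 (0.20 log units; within the scatter), and a 1.0-fold lower number from compound 1 to compound 3 (0.01 log units; within the scatter). The earlier pair varied only the iodo group on the aromatic ring, whereas compound 3 has no ring at this place at all and its number still stays within the scatter of both others. Among these compounds, then, an aromatic ring on this carbonyl carbon is not needed to keep the number in this range, and nothing on hand accounts for that result.

Going by these compounds, what stays open is whether any group at this place can move the number beyond the scatter. A longer chain such as butyl, or a chain ending in an amine or a carboxylic acid, would test this.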